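The source may report more compounds than this note shows. Statements on the series, on what has been measured and on what is new or still open speak of the compounds shown alone.

Three related compounds have been tested in a functional assay on MCF7 cells (Homo sapiens) for cytotoxicity, read by fluorescence, with a stated time of 72 h; on this read-out higher numbers stand for weaker inhibition and lower numbers for stronger inhibition. Compound 1, `Nc1nn(C(=O)c2ccc([N+](=O)[O-])cc2)c(N)c1/N=N/c1ccc(O)cc1`, does not yield a number there, only a limit of > 25000 nM. Compound 2, `Nc1n[nH]c(N)c1/N=N/c1cccc[n+]1[O-]`, also yields only a limit, > 100000 nM. Among the compounds with values here, compound 3, `Cn1nc(N)c(/N=N/c2ccncc2)c1N`, is the only one with a true number, 37700 nM. Going by these compounds, compound 1 therefore stands among the two compounds that gave a limit, and its real value remains unknown.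

Compound 4, `Nc1nn(C(=O)c2cccs2)c(N)c1/N=N/c1ccc(O)cc1`, keeps the core of compound 1 but carries thiophen-2-yl in place of 4-nitrophenyl on a carbonyl carbon. Within the data shown here, no measured pair of compounds shows what a change at this place does in this assay. Among the measured compounds shown here, the only true number is that of compound 3 at 37700 nM, so no step beyond the usual scatter is expected, in either direction. The expected change is a step that the limit leaves unreadable from compound 1 to compound 4, and this is an estimate resting on very little data. Compound 4 is estimated at 30000 nM, with an expected range from 10000 nM to 90000 nM.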

Compound 4, half-maximal inhibitory concentration: > 25000 nM
Compound 4: no number, only a limit; the forecaster's own chance of this, stated with the estimate: 50%; the middle value lies beyond the limit too.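

Compound 1 and compound 4 both give only a limit in this assay, not a number, so no step can be read between them: the limit of > 25000 nM in this assay, at which 2 of the 4 values shown sit.

The compounds shown leave open what thiophen-2-yl in place of 4-nitrophenyl on a carbonyl carbon does in this assay.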